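A few compounds are considered here, and "the series" means these few. Any claim that something is new, unique, unknown or untested is made for them only; others in the source may bear on it.

Compound 1 `CNC(=O)c1cc(Oc2ccc(/C=C/c3ccccn3)cc2)ccn1`: 21600 nM
Compound 2 `COc1ccc(NC(=O)c2cc(Oc3ccc(/C=C/c4ccccn4)cc3)ccn2)cc1`: 30000 nM
Compound 3 `CC(C)NC(=O)c1cc(Oc2ccc(/C=C/c3ccccn3)cc2)ccn1`: a limit of the assay, > 100000 nM

The three measured compounds share one core and differ only in the group on the amide-type nitrogen. In a functional assay on HepG2 cells (Homo sapiens) for antiproliferative activity, read by CCK-8 assay, with a stated time of 48 h (a lower number here means a stronger inhibitor, a higher number a weaker inhibitor), compound 1 gives 21600 nM, the lowest of the two numbers available, and a 1.4-fold higher number from compound 1 to compound 2 (0.14 log units; within the scatter). Compound 3 reaches only (the limit of > 100000 nM in this assay, at which 1 of the 3 values shown sits). The unmeasured compound 4 `O=C(c1cc(Oc2ccc(/C=C/c3ccccn3)cc2)ccn1)N1CCCC1` carries pyrrolidin-1-yl in place of methylamino on a carbonyl carbon. Both measured steps bear on it: a 1.4-fold higher number from compound 1 to compound 2 (0.14 log units; within the scatter), and an at least 4.6-fold higher number from compound 1 to compound 3 (0.66 log units; beyond the scatter). Neither lowered the number, and the isopropyl raised it. A modest rise is therefore expected, a 2.3-fold higher number from compound 1 to compound 4 (0.36 log units; beyond the scatter). For compound 4 the estimate is 50000 nM, with a range from 15000 nM to 150000 nM.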

Compound 4, half-maximal inhibitory concentration: 27000 nM
For compound 4 the middle estimate is 1.9-fold (0.27 log units) above the measured one, and the stated range covers the measured number.
By their numbers in this assay, from the lowest: compounds 1, 4 and 2 (each within the scatter of the next). At a limit, above all of these: compound 3.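

In this assay this carbonyl carbon tolerates loss of the amide hydrogen: pyrrolidin-1-yl gives a 1.3-fold higher number from compound 1 to compound 4 (0.10 log units; within the scatter) and a 1.1-fold lower number from compound 2 to compound 4 (0.05 log units; within the scatter) and so stays level with both. A larger group therefore need not raise the number as isopropylamino did, with an at least 3.7-fold lower number from compound 3 to compound 4 (0.56 log units; beyond the scatter) on changing to the ring. Compound 3 remains a limit of the assay: the limit of > 100000 nM in this assay, at which 1 of the 4 values shown sits.

Still open, on these data alone, is whether a piperidine or morpholine ring would behave like pyrrolidin-1-yl. Also open, as far as these compounds go, is whether an amine or carboxylic acid on a longer chain could bring the number clearly lower than in compound 1.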